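The compounds below may be only part of what the source reports. "The series", "measured", "known", "first", "only" and "open" are said of these compounds alone.

Working notes on the series. Compound 3 `COc1ccc(C(=O)/C=C/c2cc(-c3cc(OC)c(OC)c(OC)c3)n[nH]2)cc1OC` stands lowest of the three numbers in hand: in a functional assay on NCI-H460 cells (Homo sapiens) for cytotoxicity, read by sulforhodamine B assay, with a stated time of 48 h, tested at 1 uM (on this read-out higher numbers stand for a weaker effect at the one concentration tested and lower numbers for a stronger effect), compound 3 gives 70%. Compound 1 `COc1cc(-c2cc(/C=C/C(=O)c3ccc(N)cc3)[nH]n2)cc(OC)c1OC` carries a 4-aminophenyl on the carbonyl carbon, and in this assay compound 1 gives 78%. Compound 2 `COc1cc(-c2cc(/C=C/C(=O)c3ccc(Cl)c(Cl)c3)[nH]n2)cc(OC)c1OC` carries a 3,4-dichlorophenyl there, and in this assay compound 2 gives 93%. The steps among these three are a number 15 percentage points higher from compound 1 to compound 2 (beyond the scatter), a number 8 percentage points lower from compound 1 to compound 3 (within the scatter) and a number 23 percentage points lower from compound 2 to compound 3 (beyond the scatter); each of them exchanges the whole aryl group on the carbonyl carbon.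

Compound 4 `COc1ccc(C(=O)/C=C/c2cc(-c3cc(OC)c(OC)c(OC)c3)n[nH]2)cc1` differs from compound 3 in one place: hydrogen in place of methoxy on an aromatic carbon. Going by the values given here, no measured step removes a single methoxy group, so the known steps bear on this change only indirectly. What they do show is that swapping the entire aryl group on the carbonyl carbon shifts the number by a modest amount at most, and that compound 1 and compound 3, the two aryl groups without chlorine, sit within the scatter of each other. Removing one methoxy group is a smaller change than any of these, so the step from compound 3 to compound 4 is expected to stay within the scatter, with at most a slight rise. Compound 4 is expected to give 75% in this assay, within a range from 60% to 90%. The step this estimate implies is a number 5 percentage points higher from compound 3 to compound 4 (within the scatter), expected to remain inside the usual scatter.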

Compound 4, a percentage reported as activity, at one concentration (the size of the read-out at that concentration, not a potency): 85%
For compound 4 the middle estimate is 10 percentage points below the measured one; the measured number falls inside the stated range.
By their numbers in this assay, from the lowest: compounds 3, 1, 4 and 2 (each within the scatter of the next, the first and the last beyond it).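

In this assay, the methoxy group ortho to a methoxy group and meta to a large group counts on its own: going from 3,4-dimethoxyphenyl to 4-methoxyphenyl gives a step beyond the scatter (a number 15 percentage points higher from compound 3 to compound 4 (beyond the scatter)), as large as the exchange of a whole aryl group (a number 15 percentage points higher from compound 1 to compound 2 (beyond the scatter)). Compound 4 can be told apart neither from the 3,4-dichlorophenyl compound (a number 8 percentage points lower from compound 2 to compound 4 (within the scatter)) nor from the 4-aminophenyl compound (a number 7 percentage points higher from compound 1 to compound 4 (within the scatter)). The earlier gap between the dimethoxy and dichloro compounds (a number 23 percentage points lower from compound 2 to compound 3 (beyond the scatter)) therefore depends on this single methoxy group, since without it that gap falls within the scatter.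

Nothing in hand gives a reason for the size of this step. From the compounds shown here alone, it also remains open whether the step belongs to the methoxy group specifically or would follow any substituent on that carbon, as a hydroxy group, a fluorine atom or an ethoxy group there would show, and all of these numbers come from a single concentration.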